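A few compounds are considered here, and "the series" means these few. Any claim that something is new, unique, unknown or untested is made for them only; others in the source may bear on it.

Working notes on the series.

The shared core of compound 1 `COc1ccc(-c2cc(=O)c3c(O)cc(OCCCCN4CCN(C)CC4)c(OC)c3o2)cc1` carries a 4-methoxyphenyl group. In a functional assay on MCF7 cells (Homo sapiens) for cytotoxicity, read by MTT assay, with a stated time of 72 h (a higher number here means a weaker inhibitor, a lower number a stronger inhibitor), compound 1 gives 3980 nM. Compound 2 `COc1c(OCCCCN2CCN(C)CC2)cc(O)c2c(=O)cc(-c3ccc(C)cc3)oc12` differs from it only in the group on that phenyl ring; in this assay compound 2 gives 4020 nM. Among the measured compounds shown here, the step of a 1.0-fold higher number from compound 1 to compound 2 (0.00 log units; within the scatter) is within the scatter, so compound 1 and compound 2 stand together with no separation between them on the numbers so far.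

Compound 3 `COc1c(OCCCCN2CCN(C)CC2)cc(O)c2c(=O)cc(-c3ccc(Cl)cc3)oc12` is the next member: chloro in place of methoxy on an aromatic carbon. For the measured compounds named here, the only measured step that bears on this position is the one from compound 1 to compound 2, a methyl in place of methoxy on the same aromatic carbon, and it gave no change beyond the scatter. On that basis no step beyond the scatter is expected in this assay for the exchange of methoxy for chloro either; the expected step is a 1.0-fold higher number from compound 1 to compound 3 (0.00 log units; within the scatter). Going by the values given here, with only one step on the phenyl ring available, the range is kept wide. Compound 3 is therefore estimated at 4000 nM, between 1800 nM and 9000 nM.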

Compound 3, half-maximal inhibitory concentration: 3210 nM
Beside the measured number, compound 3's estimate is 1.2-fold (0.10 log units) above it; the measured number falls inside the stated range.
By their numbers in this assay, from the lowest: compounds 3, 1 and 2 (each within the scatter of the next).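

Working across the phenyl ring, in this assay the exchange of 4-methoxyphenyl for 4-chlorophenyl gives a 1.2-fold lower number from compound 1 to compound 3 (0.09 log units; within the scatter), and chloro in place of methyl on the same aromatic carbon gives a 1.3-fold lower number from compound 2 to compound 3 (0.10 log units; within the scatter). Among the compounds shown here, compound 1 and compound 2 alone showed only that a methyl group and a methoxy group could not be told apart here; compound 3 extends this to a single chlorine atom, a group with no carbon or oxygen, and all three pairs among compound 1, compound 2 and compound 3 now stand within the scatter. The position therefore shows no separation for these three groups in this cell assay, and no measurement at hand speaks to what lies behind that.

From the compounds shown here alone, whether this holds only for these small groups remains open: an amine or a carboxylic acid on the same aromatic carbon could still separate from compound 1. The shared core also keeps one chain throughout compound 1, compound 2 and compound 3, so the effect of a longer chain at that point cannot be read from these compounds.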